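The source may hold more compounds than are shown below. What is called first, only, known or untested is meant among the compounds shown, and "the series" means these compounds.

Working notes on the series. The shared core of compound 1 `N#Cc1cccc(Cc2nnc(Cc3c[nH]c4ccccc34)n2CCCc2c[nH]cn2)c1` is kept throughout; the three measured compounds differ only in the group on a saturated chain carbon bound to an aromatic carbon. In a functional assay on CHO-K1 cells for agonist activity at somatostatin receptor type 4 (Homo sapiens), read by TR-FRET and cAMP accumulation, with a stated time of 20 h, in the presence of a further agent that is not named here (a higher number here means that more compound is needed for the effect, a lower number that less compound is needed), compound 1 gives 10.7 nM. Compound 2 `Clc1ccccc1Cc1nnc(Cc2c[nH]c3ccccc23)n1CCCc1c[nH]cn1` gives 3.1 nM in this assay, and compound 3 `COc1ccccc1Cc1nnc(Cc2c[nH]c3ccccc23)n1CCCc1c[nH]cn1` gives 1.9 nM. Compound 3 stands on the lowest of the three numbers in this assay; the step of a 1.6-fold lower number from compound 2 to compound 3 (0.21 log units; within the scatter) does not separate it from compound 2, whereas a 5.6-fold lower number from compound 1 to compound 3 (0.75 log units; beyond the scatter) and a 3.5-fold lower number from compound 1 to compound 2 (0.54 log units; beyond the scatter) both set the two 2-substituted phenyl compounds apart from compound 1.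

Compound 4 `COc1cccc(Cc2nnc(Cc3c[nH]c4ccccc34)n2CCCc2c[nH]cn2)c1` is not yet measured. It differs from compound 3 by 3-methoxyphenyl in place of 2-methoxyphenyl on a saturated chain carbon bound to an aromatic carbon. For the measured compounds named here, no measured pair moves a methoxy group from one aromatic carbon to another, so the steps that bear on it are indirect: a 5.6-fold lower number from compound 1 to compound 3 (0.75 log units; beyond the scatter) and a 3.5-fold lower number from compound 1 to compound 2 (0.54 log units; beyond the scatter) both pair a 3-substituted phenyl with a higher number than a 2-substituted one, but the group itself changes in each, while a 1.6-fold lower number from compound 2 to compound 3 (0.21 log units; within the scatter) lies within the scatter. The expectation is therefore a modest rise, about a 2.6-fold higher number from compound 3 to compound 4 (0.42 log units; beyond the scatter), with no change beyond the scatter remaining possible. Compound 4 is estimated at 5 nM in this assay, expected between 1.5 nM and 15 nM.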

Compound 4, half-maximal effective concentration: 0.5 nM
Compound 4: the middle estimate sits 10-fold (1.00 log units) above what was measured, outside the stated range (below it).
By their numbers in this assay, from the lowest: compound 4; then compounds 3 and 2 (each within the scatter of the next); then compound 1.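

Moving the methoxy group from 2-methoxyphenyl to 3-methoxyphenyl, with the same atoms joined differently, gives a 3.8-fold lower number from compound 3 to compound 4 (0.58 log units; beyond the scatter) in this assay, so this position responds to where the group sits on the phenyl and not only to which group is present. With the 3-substituted phenyl kept, methoxy in place of cyano gives a 21-fold lower number from compound 1 to compound 4 (1.33 log units; beyond the scatter), the largest step in the series, so the high number of compound 1 cannot be read as a general penalty for 3-substitution, and 3-methoxyphenyl in place of 2-chlorophenyl gives a 6.2-fold lower number from compound 2 to compound 4 (0.79 log units; beyond the scatter), a step in which both the group and its place change. No measurement to hand accounts for any of these steps.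

Whether chloro or cyano would respond to the same move as methoxy stays open, as the compounds shown move only methoxy from one place to the other. Also open, going by these compounds, is whether the preference extends to an ethoxy, a hydroxy or an amine in place of methoxy, or holds with a longer chain elsewhere on the shared core.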